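Changing the aryl group on a shared urea core

This account rests on a few compounds, and the source may have more. Where it says the series, first, only, none or still open, it means among the compounds named here.

Compound 1 `CCc1ccc(Nc2cc(NC(=O)Nc3cc(OC)cc(OC)c3)ncn2)cc1`: 78%
Compound 2 `COc1ccc(F)cc1Nc1cc(NC(=O)Nc2c(Cl)cccc2Cl)ncn1`: 85.5%
Compound 3 `COc1cc(NC(=O)Nc2cc(Nc3cccc(C(C)(C)C)c3)ncn2)cc(OC)c1`: 68%

In a functional assay on PC-9 cells (Homo sapiens) for inhibition, read by MTT assay, with a stated time of 48 h, tested at 10 uM (a lower number here means less inhibition, a higher number more inhibition at the concentration tested (going by the name of the read-out)), compound 3 gives 68%, the lowest of the three numbers. Compound 1 gives 78%, within the scatter of compound 3. Compound 2 gives 85.5%, beyond the scatter of compound 3. Compound 4 `COc1cc(NC(=O)Nc2cc(Nc3ccc(C)c(F)c3)ncn2)cc(OC)c1` differs from compound 3 in one place: 3-fluoro-4-methylphenyl in place of 3-(tert-butyl)phenyl on a nitrogen on an aromatic ring. Among the measured compounds shown here, the only measured step at this position, a number 10 percentage points lower from compound 1 to compound 3 (within the scatter), stayed within the scatter, so a change of the aryl group here is expected to move the number little. The step of a number 4 percentage points higher from compound 3 to compound 4 (within the scatter) is therefore estimated to lie within the scatter. Compound 4 is expected to give about 72% in this assay, with a range from 58% to 86%.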

Compound 4, a percentage reported as inhibition, at one concentration (the size of the read-out at that concentration, not a potency): 77.5%
The estimate for compound 4 lay 5.5 percentage points below the measured number; the range from low to high includes it.
By their numbers in this assay, from the lowest: compounds 3, 4, 1 and 2 (each within the scatter of the next, the first and the last beyond it).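

In this assay the change gives a number 9.5 percentage points higher from compound 3 to compound 4 (within the scatter), and measured against the other aryl group it gives a number 0.5 percentage points lower from compound 1 to compound 4 (within the scatter). All three steps among 4-ethylphenyl, 3-(tert-butyl)phenyl and 3-fluoro-4-methylphenyl on this nitrogen now stay within the scatter, and the set includes a ring carrying fluorine. No measurement here offers an explanation for these numbers. Still open, from the compounds shown here alone, is whether an amine or a carboxylic acid on this ring would move the number beyond the scatter. Compound 2 differs from these compounds in more than one place, so its number cannot be tied to this position alone.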